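The compounds below may be only part of what the source reports. "The series", "measured", "known", "first", "only" and "open" are said of these compounds alone.

Measured in a functional assay on M21 cells (Homo sapiens) for antiproliferative activity, read by sulforhodamine B assay, with a stated time of 48 h; on this read-out higher numbers stand for weaker inhibition and lower numbers for stronger inhibition:
compound 1 `O=C1NCCN1c1ccc(S(=O)(=O)Nc2ccc(OC(F)F)cc2)cc1` gives 410 nM.
compound 2 `CC(C)(C)c1ccc(NS(=O)(=O)c2ccc(N3CCNC3=O)cc2)cc1` gives > 1000 nM, a limit of the assay rather than a number.
compound 3 `O=C1NCCN1c1ccc(S(=O)(=O)Nc2ccc(F)cc2)cc1` gives 230 nM.

Compound 3 stands lowest of the two numbers; compound 1 sits nearest, and the step of a 1.8-fold lower number from compound 1 to compound 3 (0.25 log units; within the scatter) is within the scatter, so no order between the two can be claimed. For compound 2 the assay reports only a limit, (the limit of > 1000 nM in this assay, at which 1 of the 3 values shown sits).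

Compound 4 `CCCCc1ccc(NS(=O)(=O)c2ccc(N3CCNC3=O)cc2)cc1` differs from compound 3 by butyl in place of fluoro on an aromatic carbon. The measured steps that bear on this are an at least 4.3-fold lower number from compound 2 to compound 3 (0.63 log units; beyond the scatter) and an at least 2.4-fold higher number from compound 1 to compound 2 (0.38 log units; beyond the scatter): with tert-butyl on that aromatic carbon only a limit was reached, and fluoro in its place gave a clearly lower number. Butyl is closer in kind to tert-butyl than to fluoro, so the reverse movement is expected, a higher number of at least modest size. Compound 4 is therefore estimated at 1500 nM, with a range of 500 nM to 5000 nM, an expected step of a 6.5-fold higher number from compound 3 to compound 4 (0.81 log units; beyond the scatter). There is a fair chance that this assay reports only a limit for compound 4, as it does for compound 2 at > 1000 nM.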

Compound 4, half-maximal inhibitory concentration: 450 nM
The estimate for compound 4 lay 3.3-fold (0.52 log units) above the measured number, outside the stated range (below it).
By their numbers in this assay, from the lowest: compounds 3, 1 and 4 (each within the scatter of the next). At a limit, above all of these: compound 2.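

In this assay, butyl on the aromatic carbon para to a large group stays level with the smaller groups tested there: the steps are a 2.0-fold higher number from compound 3 to compound 4 (0.29 log units; within the scatter) and a 1.1-fold higher number from compound 1 to compound 4 (0.04 log units; within the scatter). Against tert-butyl the result separates, with an at least 2.2-fold lower number from compound 2 to compound 4 (0.34 log units; beyond the scatter), so the earlier link between an alkyl group at this position and a weak read-out holds for tert-butyl but not for alkyl groups in general. Within the data shown here, compound 2 remains the only compound given as a limit rather than a number: the limit of > 1000 nM in this assay, at which 1 of the 4 values shown sits.

Going by these compounds, whether this tolerance extends to a longer chain such as hexyl, or to an amine or a carboxylic acid at the same position, stays open. On these data alone, the actual number for compound 2 also stays open, so the gap between butyl and tert-butyl has no upper end.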